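The compounds below may be only part of what the source reports. "The series", "measured", "known", "first", "only" and "open" are said of these compounds alone.

In a functional assay on HGC-27 cells (Homo sapiens) for inhibition, read by MTT assay, with a stated time of 72 h (a higher number here means a weaker inhibitor, a lower number a stronger inhibitor), compound 3 (`Cc1cc(N2CC[C@@H](C)[C@@H](N(C)c3ncnc4[nH]ccc34)C2)n2nc(SCc3nc4ccccc4[nH]3)nc2n1`) gives > 100000 nM, which is a limit of the assay and not a number. Compound 1 (`Cc1cc(N2CC[C@@H](C)[C@@H](N(C)c3ncnc4[nH]ccc34)C2)n2nc(SCc3ccc(Cl)cc3)nc2n1`) gives 18400 nM, and compound 2 (`Cc1cc(N2CC[C@@H](C)[C@@H](N(C)c3ncnc4[nH]ccc34)C2)n2ncnc2n1`) gives 11300 nM. Compound 4 (`Cc1cc(N2CC[C@@H](C)[C@@H](N(C)c3ncnc4[nH]ccc34)C2)n2nc(SCc3csc4ccc(Cl)cc34)nc2n1`) has 5-chloro-1-benzothiophen-3-yl in place of 1H-benzimidazol-2-yl on a saturated chain carbon bound to a sulfur.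

Among the measured compounds shown here, three measured steps bear on this change. Hydrogen in place of (4-chlorobenzyl)sulfanyl gave a 1.6-fold lower number from compound 1 to compound 2 (0.21 log units; within the scatter). 1H-benzimidazol-2-yl in place of 4-chlorophenyl gave an at least 5.4-fold higher number from compound 1 to compound 3 (0.73 log units; beyond the scatter), the same group that compound 4 gives up. The full ((1H-benzimidazol-2-yl)methyl)sulfanyl in place of hydrogen gave an at least 8.8-fold higher number from compound 2 to compound 3 (0.94 log units; beyond the scatter).

The entering group carries chlorine, as the 4-chlorophenyl of compound 1 does, so the step of an at least 5.4-fold higher number from compound 1 to compound 3 (0.73 log units; beyond the scatter) is expected to be largely reversed, toward a lower number in this assay. The expected change is an at least 5.5-fold lower number from compound 3 to compound 4 (0.74 log units; beyond the scatter). For compound 4 the estimate is 18000 nM, with an expected range of 6000 nM to 55000 nM.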

Compound 4, half-maximal inhibitory concentration: > 100000 nM
Compound 4 gave a limit, no number; the forecaster's own chance of this, stated with the estimate: 12%; middle value at least 5.5-fold (0.74 log units) away from the limit.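

In this assay compound 4 gives > 100000 nM, which is a limit of the assay and not a number, and the step between compound 3 and compound 4 cannot be read. The comparisons with the other compounds can be read: the full ((5-chloro-1-benzothiophen-3-yl)methyl)sulfanyl in place of hydrogen gave an at least 8.8-fold higher number from compound 2 to compound 4 (0.94 log units; beyond the scatter), and 5-chloro-1-benzothiophen-3-yl in place of 4-chlorophenyl gave an at least 5.4-fold higher number from compound 1 to compound 4 (0.73 log units; beyond the scatter). Chlorine in the entering group therefore did not restore the standing of compound 1, and on this saturated chain carbon bound to a sulfur, two different groups, each with one five-membered and one six-membered aromatic ring, end at the same limit: the limit of > 100000 nM in this assay, at which 2 of the 4 values shown sit.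

As far as these compounds go, how far compound 3 and compound 4 actually lie from each other remains open. Also open, from the compounds shown here alone, is whether an amine or a carboxylic acid on this saturated chain carbon would stay near compound 1 or reach that limit too.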